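The source may hold more compounds than are shown below. What is called first, only, known or untested is meant among the compounds shown, and "the series" means these compounds.

In a functional assay on DU-145 cells (Homo sapiens) for cytotoxicity, read by MTT assay, with a stated time of 72 h (a lower number here means that less compound is needed, a higher number that more compound is needed for the effect), compound 1 `CCc1cccc2c(O)c(-c3occ(C)c3C(=O)O)ccc12` gives 8.7 ug/mL. Compound 2 `CCc1cccc2c(OC)c(-c3occ(C)c3C(=S)OC)ccc12` gives 5.7 ug/mL in this assay. Compound 3 `CCc1cccc2c(OC(C)=O)c(-c3occ(C)c3COC(C)=O)ccc12` reaches only a limit of the assay, > 10 ug/mL, and so offers no number. Compound 2 thus carries the lowest of the two numbers, yet compound 1 is its nearest neighbour and the gap between them lies within the scatter, so the two cannot be ranked against each other. The limit of > 10 ug/mL in this assay, at which 1 of the 3 values shown sits, is where compound 3 stands.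

Compound 4 `CCc1cccc2c(OC)c(-c3occ(C)c3CBr)ccc12` has not been measured. It differs from compound 2 by a group of 2 heavy atoms (1 carbon, 1 bromine; no ring) in place of a group of 4 heavy atoms (2 carbon, 1 oxygen, 1 sulfur; no ring), on an aromatic carbon. For the measured compounds named here, no measured pair in this set shows such a change, so its size has to be guessed. The expected step of a 1.4-fold lower number from compound 2 to compound 4 (0.15 log units; within the scatter) is toward a lower number, of a size that may not clear the scatter. Compound 4 is therefore estimated at 4 ug/mL, within a range from 1.5 ug/mL to 10 ug/mL.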

Compound 4, concentration for half-maximal effect: > 10 ug/mL
Compound 4: only a limit was reported (the forecaster's own chance of this, stated with the estimate: 20%); at least 2.5-fold (0.39 log units) between middle value and limit.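

For the compounds shown here, this is the first readable step at this place on the five-membered aromatic ring, two ring bonds from the ring oxygen: bromomethyl in place of the earlier group gives an at least 1.7-fold higher number from compound 2 to compound 4 (0.24 log units; that floor lies within the scatter) in this assay. The step shows that this change does not lead to a lower number, although its floor lies within the scatter, so no firm loss can be claimed from the floor alone. The reading of compound 4 is a limit and not a number, and such limits make up a large share of this small set: the limit of > 10 ug/mL in this assay, at which 2 of the 4 values shown sit.

From the compounds shown here alone, how far compound 4 lies past its limit stays open, and so does the true size of the step. Also open, going by these compounds, is whether an amine, a carboxylic acid or a longer chain at this place would give a measurable number.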